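Aryl substituent steps on the shared core

The compounds below may be only part of what the source reports. "The series", "measured", "known", "first", "only" and "open" are said of these compounds alone.

Three measured compounds share one core and differ only in the group on the aryl ring. In a functional assay on HT-29 cells (Homo sapiens) for cytotoxicity, read by sulforhodamine B assay (on this read-out lower numbers stand for stronger inhibition of growth and higher numbers for weaker inhibition of growth), compound 1 `CC1=CC[C@@H]([C@@](C)(O)CCCC(C)(C)NC(=S)N/N=C\c2ccc(C)cc2)CC1` gives 10400 nM. Compound 2 `COc1ccc(/C=N\NC(=S)NC(C)(C)CCC[C@](C)(O)[C@@H]2CC=C(C)CC2)cc1` gives 7420 nM, and compound 3 `CC1=CC[C@@H]([C@@](C)(O)CCCC(C)(C)NC(=S)N/N=C\c2ccc(O)cc2)CC1` gives 8150 nM. The steps of a 1.4-fold lower number from compound 1 to compound 2 (0.15 log units; within the scatter), a 1.3-fold lower number from compound 1 to compound 3 (0.11 log units; within the scatter) and a 1.1-fold higher number from compound 2 to compound 3 (0.04 log units; within the scatter) all lie within the scatter, so compound 3 sits in the same band as both others. Compound 4 `CC1=CC[C@@H]([C@@](C)(O)CCCC(C)(C)NC(=S)N/N=C\c2ccc(N(C)C)cc2)CC1` carries dimethylamino in place of hydroxy on an aromatic carbon. Every measured exchange at this position, methoxy, hydroxy or methyl, left the number within the scatter, so no step beyond the scatter is expected in this assay. The step expected from this change is a 1.0-fold lower number from compound 3 to compound 4 (0.01 log units; within the scatter). Compound 4 is estimated at 8000 nM, with a range from 3000 nM to 22000 nM.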

Compound 4, concentration for 50% growth inhibition: 27700 nM
Compound 4: the middle estimate sits 3.5-fold (0.54 log units) below what was measured; measured number outside the range, above it.
By their numbers in this assay, from the lowest: compounds 2, 3 and 1 (each within the scatter of the next); then compound 4.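

Dimethylamino is the first group at this position to move the number beyond the scatter in this assay, with a 3.4-fold higher number from compound 3 to compound 4 (0.53 log units; beyond the scatter) and a 3.7-fold higher number from compound 2 to compound 4 (0.57 log units; beyond the scatter) and a 2.7-fold higher number from compound 1 to compound 4 (0.43 log units; beyond the scatter) all on the side of weaker inhibition of growth. The position therefore does not tolerate every exchange, even though methyl, methoxy and hydroxy stay within the scatter of one another. Nothing measured here explains this step.

Going by these compounds, whether the shift is specific to dimethylamino remains open, since an unsubstituted amine or a methylamino group on the same aromatic carbon would test that. Also open, on these data alone, is whether a carboxylic acid or a chlorine there would stay level with compound 1, compound 2 and compound 3.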